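This account rests on a few compounds, and the source may have more. Where it says the series, first, only, none or still open, it means among the compounds named here.

Measured in an in vivo ADME assay on the whole organism (strain Sprague-Dawley) for pharmacokinetics, with Rattus norvegicus as the target, at a dose of 2 mg/kg by the intravenous route; on this read-out lower numbers stand for slow clearance and higher numbers for fast clearance:
Compound 1, `Cc1ccc(C(=O)NC2CC2)cc1-c1cc2cnnc(-c3ccc(F)cc3F)c2n(C)c1=O`: 3.83 mL/min/kg
Compound 2, `Cc1ccc(C(=O)NC2(C)CC2)cc1-c1cc2cnnc(-c3ccc(F)cc3F)c2n(C)c1=O`: 5 mL/min/kg
Compound 3, `Cc1cnc(C(=O)NC2CC2)cc1-c1cc2cnnc(-c3ccccc3C)c2n(C)c1=O`: 81.8 mL/min/kg

Compound 3 gives the highest number of the three, and its gaps to compound 1 and compound 2 both lie beyond the scatter. Compound 4, `Cc1cnc(C(=O)NC2CC2)cc1-c1cc2cnnc(-c3ccccc3Cl)c2n(C)c1=O`, differs from compound 3 by chloro in place of methyl on an aromatic carbon. Among the compounds with values here, the one measured step, a 1.3-fold higher number from compound 1 to compound 2 (0.12 log units; within the scatter), concerns a change on a saturated ring carbon, not on the aromatic ring, and it stayed within the scatter. Within the data shown here, no measured step bears directly on swapping methyl for chloro at this place, so the plain expectation is a number close to that of compound 3. The expected step is a 1.2-fold lower number from compound 3 to compound 4 (0.07 log units; within the scatter). Compound 4 is therefore estimated at 70 mL/min/kg, between 30 mL/min/kg and 150 mL/min/kg.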

Compound 4, clearance: 13.2 mL/min/kg
For compound 4 the middle estimate is 5.3-fold (0.72 log units) above the measured one; the measured number lies below the stated range.
By their numbers in this assay, from the lowest: compounds 1 and 2 (each within the scatter of the next); then compound 4; then compound 3.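

Exchanging one heavy atom for another on this aromatic carbon, ortho to a large group, changes the number clearly in this assay: going from 2-methylphenyl to 2-chlorophenyl gives a 6.2-fold lower number from compound 3 to compound 4 (0.79 log units; beyond the scatter). Within the data shown here, the earlier step, on a saturated ring carbon, stayed within the scatter, so this is the first sign that a small exchange can shift clearance. Nothing shown here explains the drop.

As far as these compounds go, whether a methoxy or nitrile group at this carbon would give a lower or higher number stays open. So does whether chloro would have a similar effect in other compounds of this series.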